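Fluoro on the fused benzene ring: effect on dose

The source may report more compounds than this note shows. Statements on the series, on what has been measured and on what is new or still open speak of the compounds shown alone.

Compound 2 `O=C1Nc2ccccc2C1CCCCN1CCN(c2cccc(Cl)c2)CC1` and compound 1 `O=C1Nc2ccc(F)cc2C1CCCCN1CCN(c2cccc(Cl)c2)CC1` share a core and are both tested in a functional assay on the whole organism (strain Wistar) with Rattus norvegicus as the target, with a stated time of 5 min; on this read-out lower numbers stand for an effect already at smaller amounts and higher numbers for an effect only at larger amounts of compound. For compound 2 the result is a limit of the assay, < 5 mg/kg. For compound 1 the result is likewise a limit, > 20 mg/kg. The difference between the two is fluoro in place of hydrogen on an aromatic carbon, and it gives an at least 4.0-fold higher number from compound 2 to compound 1 (0.60 log units; beyond the scatter), both ends resting on limits, the limit of < 5 mg/kg in this assay, at which 1 of the 3 values shown sits, and (the limit of > 20 mg/kg in this assay, at which 1 of the 3 values shown sits). Compound 3 `CCC1(CCCCN2CCN(c3ccc(Cl)cc3)CC2)C(=O)Nc2ccccc21` carries another core; the difference between the cores of compound 3 and compound 2 is not broken down here. In this assay, among the compounds with values here, compound 3 gives 10 mg/kg, the only number among the three. Compound 4 `CCC1(CCCCN2CCN(c3ccc(Cl)cc3)CC2)C(=O)Nc2cc(F)ccc21` differs from compound 3 by fluoro in place of hydrogen on an aromatic carbon, the same change as between compound 2 and compound 1. Compound 4 is expected to follow a 3.0-fold higher number from compound 3 to compound 4 (0.48 log units; beyond the scatter), resting on an at least 4.0-fold higher number from compound 2 to compound 1 (0.60 log units; beyond the scatter). Compound 4 is therefore estimated at 30 mg/kg, within 12 mg/kg to 80 mg/kg, and a limit rather than a number is a real possibility.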

Compound 4, minimum effective dose: > 20 mg/kg
Compound 4 was reported as a limit (the forecaster's own chance of this, stated with the estimate: 50%); the middle value lies beyond the limit too.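

On the second core, fluoro in place of hydrogen on an aromatic carbon gives an at least 2.0-fold higher number from compound 3 to compound 4 (0.30 log units; that floor lies within the scatter) in this assay. Both pairs point the same way, but the size of the step cannot be compared between the cores: the same change on two cores in this assay, an at least 4.0-fold higher number (0.60 log units; beyond the scatter) from compound 2 to compound 1 and an at least 2.0-fold higher number (0.30 log units; that floor lies within the scatter) from compound 3 to compound 4; the limit leaves it open whether they differ. The two pairs therefore give only floors, not a size for the change on either core, and they establish no rule for any further core.

The compounds shown leave open how far the true doses lie past the limits on the fluoro compounds. They also leave open whether chloro or methoxy on the same aromatic carbon would give a step like that of fluoro.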